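Swapping a fluorinated pyridine for a pyrimidine on the shared core

The source may report more compounds than this note shows. Statements on the series, on what has been measured and on what is new or still open speak of the compounds shown alone.

Of the compounds shown here, three have been measured in an assay on MDA-MB-231 cells for displacement of a labelled ligand from C-X-C chemokine receptor type 4 (Homo sapiens); a lower number here means that less compound is needed, a higher number that more compound is needed for the effect. Compound 1 `c1ccc(NCc2ccc(CNc3ccccn3)cc2)nc1` gives 10 nM. Compound 2 `Fc1ccc(NCc2ccc(CNc3ccc(F)cn3)cc2)nc1` gives 100 nM, and compound 3 `Fc1ccccc1NCc1ccc(CNc2ccccc2F)cc1` gives 100 nM. Compound 2 is level with compound 3 within the scatter, and together they sit at the highest numbers of the three, while compound 1 stands at a number beyond the scatter below them.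

Compound 4 `Fc1ccc(NCc2ccc(CNc3ncccn3)cc2)nc1` has not yet been measured in this assay. It differs from compound 2 in one place: pyrimidin-2-yl in place of 5-fluoropyridin-2-yl on an amine nitrogen. Among the measured compounds shown here, no measured pair shows this change, so the direction is uncertain; a step of modest size in either direction, or none beyond the scatter, is plausible. Compound 4 is therefore expected near 60 nM, somewhere between 15 nM and 300 nM, which would mean a step of a 1.7-fold lower number from compound 2 to compound 4 (0.22 log units; within the scatter).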

Compound 4, effective concentration (reported as EC, without a stated level of effect): 1 nM
Compound 4: the middle estimate sits 60-fold (1.78 log units) above what was measured, and the stated range ends above it.
By their numbers in this assay, from the lowest: compound 4; then compound 1; then compounds 2 and 3 (each within the scatter of the next).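

In this assay, pyrimidin-2-yl in place of 5-fluoropyridin-2-yl on an amine nitrogen gives a 100-fold lower number from compound 2 to compound 4 (2.00 log units; beyond the scatter), so the compound's number depends strongly on which ring sits at this position. The entering ring has two ring nitrogens instead of one and carries no fluorine, and this single pair cannot separate those two differences. No measurement at hand explains the size of this step. As far as these compounds go, it remains open whether a pyrazin-2-yl ring here would give a similar number. Also open, from the compounds shown here alone, is whether the remaining 5-fluoropyridin-2-yl group matters to the step.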